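A few compounds are considered here, and "the series" means these few. Any claim that something is new, unique, unknown or untested is made for them only; others in the source may bear on it.

In a functional assay on OVCAR-5 cells (Homo sapiens) for inhibition, with a stated time of 48 h, tested at 50 uM (on this read-out higher numbers stand for more inhibition of growth at the one concentration tested and lower numbers for less inhibition of growth), compound 1 `C=C[C@@](C)(/C=C/c1ccc(OC(=O)CCC)cc1)CCC=C(C)C` gives 41% and compound 2 `C=C[C@@](C)(/C=C/c1ccc(OC(=O)CCCCC)cc1)CCC=C(C)C` gives 13% as the lower of the two numbers. Compound 3 `C=C[C@@](C)(/C=C/c1ccc(OC(=O)CCCCCCC)cc1)CCC=C(C)C` shares the core of both but has not yet been measured in this assay at this stage. Its structure departs from that of compound 2 by ethyl in place of hydrogen on a saturated chain carbon, five bonds along the chain from a carbonyl carbon on the same chain, with ethyl in place of hydrogen on a saturated chain carbon, five bonds along the chain from a carbonyl carbon. Going by the values given here, the one measured step that bears on this change is a number 28 percentage points lower from compound 1 to compound 2 (beyond the scatter) for ethyl in place of hydrogen on a saturated chain carbon, three bonds along the chain from a carbonyl carbon. That step is modest but beyond the scatter, and a single step does not establish a trend. A further fall is expected in this assay but a smaller one, since compound 2 at 13% has little left to lose. The expected change is a number 5 percentage points lower from compound 2 to compound 3 (within the scatter) in this estimate. For compound 3 the estimated value is 8% with an expected range of 0% to 25% in the same read-out.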

Compound 3, percent growth inhibition at one concentration: 42%
Beside the measured number, compound 3's estimate is 34 percentage points below it; the whole stated range lies below it.
By their numbers in this assay, from the lowest: compound 2; then compounds 1 and 3 (each within the scatter of the next).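

In this assay the ethyl in place of hydrogen on a saturated chain carbon, five bonds along the chain from a carbonyl carbon, gives a number 29 percentage points higher from compound 2 to compound 3 (beyond the scatter) and so runs opposite to the earlier ethyl step, three bonds along the chain from a carbonyl carbon. Extending this chain therefore does not steadily lower growth inhibition in these three compounds: compound 2 is the lowest of them, with its steps to both others beyond the scatter, and compound 3 goes against any fall with chain length. Taken as one change, the two ethyl steps together give a number 1 percentage points higher from compound 1 to compound 3 (within the scatter) and so offset each other in this read-out.

The compounds shown leave open whether a longer chain than that of compound 3 would hold this level of growth inhibition, and whether an amine or a carboxylic acid at the end of the chain would change it. Nothing given here accounts for the reversal along the chain.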